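Nitro for chloro on the N-aryl ring: cytotoxicity notes

The source may hold more compounds than are shown below. What is called first, only, known or untested is meant among the compounds shown, and "the series" means these compounds.

Measured so far:
compound 1 `COc1ccc(C2=Cc3ccc(F)cc3C(CC(=O)CO)N2c2ccc([N+](=O)[O-])cc2)cc1` gives 46400 nM in an ADME assay on TZM cells (Homo sapiens) for cytotoxicity, read by CellTiter-Glo, with a stated time of 48 h; a higher number here means that more compound is tolerated, a lower number that less compound is tolerated
compound 2 `COc1ccc(C2=Cc3ccc(F)cc3C(CC(=O)C(C)O)N2c2ccc(Cl)cc2)cc1` gives 9900 nM in this assay

Of the two numbers shown, compound 2 stands lowest in this assay; compound 1 sits at the higher value, and the gap between them lies beyond the scatter. The two differ in more than one place, so the gap cannot be assigned to either change alone.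

Compound 3 `COc1ccc(C2=Cc3ccc(F)cc3C(CC(=O)C(C)O)N2c2ccc([N+](=O)[O-])cc2)cc1` is not yet measured. It differs from compound 2 by nitro in place of chloro on an aromatic carbon; the rest of the molecule is unchanged. Compound 3 thus shares its N-aryl ring with compound 1 and its side chain with compound 2. Within the data shown here, with no single-change step available, the expectation rests on the higher value of compound 1 in this assay: a rise toward it is expected, though of uncertain size. The step of a 2.5-fold higher number from compound 2 to compound 3 (0.40 log units; beyond the scatter) is the expected outcome. Compound 3 is expected to give about 25000 nM in this assay, within 8000 nM to 70000 nM.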

Compound 3, half-maximal cytotoxic concentration: 10100 nM
Estimate against measurement, compound 3: 2.5-fold (0.39 log units) above; the range from low to high includes it.
By their numbers in this assay, from the lowest: compounds 2 and 3 (each within the scatter of the next); then compound 1.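

Within this assay, nitro in place of chloro on an aromatic carbon, with the rest of the molecule unchanged, leaves the number within the scatter (a 1.0-fold higher number from compound 2 to compound 3 (0.01 log units; within the scatter)), so the change from 4-chlorophenyl to 4-nitrophenyl does not by itself account for the higher number of compound 1. Among these compounds, the single change that does separate two values lies on the side chain, methyl in place of hydrogen on a saturated chain carbon bound to a carbonyl carbon and an oxygen (a 4.6-fold lower number from compound 1 to compound 3 (0.66 log units; beyond the scatter)), a modest step beyond the scatter. No measurement at hand gives a reason for either step.

From the compounds shown here alone, it remains open whether the methyl step carries over to a compound with the 4-chlorophenyl ring, and how a longer chain on that same carbon would read. Also open, going by these compounds, is whether an amine or a nitrile in place of chloro on that aromatic carbon would stay level with compound 2 and compound 3.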